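Swapping the triazole for an ethynyl thiazole in a macrocycle

This account rests on a few compounds, and the source may have more. Where it says the series, first, only, none or still open, it means among the compounds named here.

The measured compounds and their values:
Compound 1, `COc1ccc2c(O[C@H]3C[C@H]4C(=O)N(C)CCCC/C=C/[C@@H]5C[C@@]5(C(=O)NS(=O)(=O)C5(C)CC5)NC(=O)N4C3)cc(-c3nc(C4CCC4)cs3)nc2c1Cl`, gives 75000 nM in an ADME assay on Huh-7 cells (Homo sapiens) for cytotoxicity, read by colorimetric assay; a higher number here means that more compound is tolerated, a lower number that less compound is tolerated.
Compound 2, `COc1ccc2c(O[C@H]3C[C@H]4C(=O)N(C)CCCC/C=C/[C@@H]5C[C@@]5(C(=O)NS(=O)(=O)C5(C)CC5)NC(=O)N4C3)cc(-c3csc(C(F)(F)F)n3)nc2c1Cl`, gives 59000 nM in this assay.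
Compound 3, `COc1ccc2c(O[C@H]3C[C@H]4C(=O)N(C)CCCC/C=C/[C@@H]5C[C@@]5(C(=O)NS(=O)(=O)C5(C)CC5)NC(=O)N4C3)cc(-n3cc(C(C)C)nn3)nc2c1Cl`, gives 28500 nM in this assay.

On these numbers compound 3 stands lowest, meaning it is the least tolerated of the three: a 2.6-fold lower number from compound 1 to compound 3 (0.42 log units; beyond the scatter) and a 2.1-fold lower number from compound 2 to compound 3 (0.32 log units; beyond the scatter). Compound 1 and compound 2 differ from each other only within the usual scatter, a 1.3-fold lower number from compound 1 to compound 2 (0.10 log units; within the scatter).

Compound 4, `C#Cc1csc(-c2cc(O[C@H]3C[C@H]4C(=O)N(C)CCCC/C=C/[C@@H]5C[C@@]5(C(=O)NS(=O)(=O)C5(C)CC5)NC(=O)N4C3)c3ccc(OC)c(Cl)c3n2)n1`, carries a new group on the shared core: 4-ethynyl-1,3-thiazol-2-yl in place of 4-isopropyl-1H-1,2,3-triazol-1-yl on an aromatic carbon. The two steps that bear on this are those that exchange a thiazole for the triazole: a 2.6-fold lower number from compound 1 to compound 3 (0.42 log units; beyond the scatter) and a 2.1-fold lower number from compound 2 to compound 3 (0.32 log units; beyond the scatter), both modest moves toward a less tolerated compound. The change to compound 4 runs the other way, putting a thiazole back in place of the triazole, so a modest rise is expected, a 2.1-fold higher number from compound 3 to compound 4 (0.32 log units; beyond the scatter). Compound 4 is therefore estimated at 60000 nM, with a range from 30000 nM to 120000 nM.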

Compound 4, half-maximal cytotoxic concentration: 17000 nM
Compound 4: the middle estimate sits 3.5-fold (0.55 log units) above what was measured, outside the stated range (below it).
By their numbers in this assay, from the lowest: compounds 4 and 3 (each within the scatter of the next); then compounds 2 and 1 (each within the scatter of the next).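

In this assay, having a thiazole at this position does not by itself give a higher number: the result is a 1.7-fold lower number from compound 3 to compound 4 (0.22 log units; within the scatter), so the triazole and this thiazole cannot be told apart here. Among the compounds shown here, the group carried by the thiazole matters, as the cleanest comparison keeps the ring and changes only that group, giving a 4.4-fold lower number from compound 1 to compound 4 (0.64 log units; beyond the scatter), while the step to the other thiazole isomer gives a 3.5-fold lower number from compound 2 to compound 4 (0.54 log units; beyond the scatter). Nothing measured here explains these differences.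

From the compounds shown here alone, it remains open whether a methyl group or an amine in place of the ethynyl on the same 1,3-thiazol-2-yl ring would stay close to compound 4 or move toward compound 1. Also open, going by these compounds, is whether ethynyl in place of isopropyl on the triazole would give a similar step.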